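The source may hold more compounds than are shown below. What is called first, only, known or untested is meant among the compounds shown, and "the series" means these compounds.

In a functional assay on HFF cells (Homo sapiens) for cytotoxicity (on this read-out lower numbers stand for stronger inhibition and higher numbers for weaker inhibition), three compounds sharing one core have been measured. Compound 1 `CCOC[C@H]1O[C@@H](n2c(Cl)nc3cc(Cl)c(Cl)cc32)[C@H](OC(C)=O)[C@@H]1OC(C)=O` gives 33000 nM, compound 2 `CCOC[C@H]1OC(n2c(Cl)nc3cc(Cl)c(Cl)cc32)[C@H](O)[C@@H]1O` gives 26000 nM, and compound 3 `O[C@@H]1[C@@H](CCl)OC(n2c(Cl)nc3cc(Cl)c(Cl)cc32)[C@@H]1O` gives 32000 nM. These values all lie within the scatter of one another, so compound 3 stands level with the other two and no order can be read among them. The next structure is compound 4 `[N-]=[N+]=NC[C@H]1OC(n2c(Cl)nc3cc(Cl)c(Cl)cc32)[C@H](O)[C@@H]1O`, which carries azido in place of chloro on a saturated chain carbon bound to a saturated ring carbon. Among the measured compounds shown here, one measured step bears on this place, a 1.2-fold higher number from compound 2 to compound 3 (0.09 log units; within the scatter), where chloro took the place of ethoxy and the number stayed within the scatter. Azido itself has not been measured in this set, so the evidence is thin. Even so, no step beyond the scatter is expected in this assay, and the estimate is a 1.1-fold lower number from compound 3 to compound 4 (0.03 log units; within the scatter). The estimated value for compound 4 is 30000 nM, with an expected range from 12000 nM to 75000 nM.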

Compound 4, half-maximal inhibitory concentration: 32000 nM
Beside the measured number, compound 4's estimate is 1.1-fold (0.03 log units) below it, within the range that was stated.
By their numbers in this assay, from the lowest: compounds 2, 3, 4 and 1 (each within the scatter of the next).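

In this assay, azido in place of chloro on a saturated chain carbon bound to a saturated ring carbon gives no change at the digits printed from compound 3 to compound 4 (within the scatter), and azido in place of ethoxy at the same carbon gives a 1.2-fold higher number from compound 2 to compound 4 (0.09 log units; within the scatter). The earlier compounds shown here compared only ethoxy and chloro at this place; azido now adds a third group, with more heavy atoms than chloro and a hydrogen-bond acceptor that chloro lacks, and the read-out still shows no separation among the three. No evidence at hand accounts for this flat result.

What the compounds shown leave open is whether an amine, a carboxylic acid or a longer chain at this place would give a step beyond the scatter. They also leave open whether ethoxy, chloro and azido stay level on any other read-out.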